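Purine ribosides at the transporter: a reversed thioether variant

This account rests on a few compounds, and the source may have more. Where it says the series, first, only, none or still open, it means among the compounds named here.

Measured so far:
compound 1 `CCCCCNc1ncnc2c1ncn2[C@@H]1O[C@H](CO)[C@@H](O)[C@H]1O`: 13500 nM
compound 2 `CSc1nc(N)nc2c1ncn2[C@@H]1O[C@H](CO)[C@@H](O)[C@H]1O`: 204000 nM

In an assay on isolated protein for binding affinity to Equilibrative nucleoside transporter 1 (Homo sapiens) (on this read-out lower numbers stand for stronger inhibition and higher numbers for weaker inhibition), compound 1 stands lowest of the two numbers; compound 2, with its different substitution on the shared core, gives the higher number, a gap beyond the scatter. Compound 3 `OC[C@H]1O[C@@H](n2cnc3c(CSc4cccc(Br)c4)ncnc32)[C@H](O)[C@@H]1O` is not yet measured. It departs from compound 1 by ((3-bromophenyl)sulfanyl)methyl in place of pentylamino on an aromatic carbon. For the measured compounds named here, no measured pair covers this change, so its size is uncertain. A step in the stronger direction, beyond the scatter, is expected from compound 1 to compound 3, a 4.5-fold lower number from compound 1 to compound 3 (0.65 log units; beyond the scatter). For compound 3 the expected value is 3000 nM, within 400 nM to 25000 nM.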

Compound 3, half-maximal inhibitory concentration: 363 nM
Compound 3: middle estimate off by 8.3-fold (0.92 log units), on the high side; the measured number lies below the stated range.
By their numbers in this assay, from the lowest: compound 3; then compound 1; then compound 2.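

In this assay, ((3-bromophenyl)sulfanyl)methyl in place of pentylamino on an aromatic carbon gives a 37-fold lower number from compound 1 to compound 3 (1.57 log units; beyond the scatter). This position therefore tolerates a group with a six-membered aromatic ring of carbon only and no hydrogen-bond donor, and the number falls well beyond the scatter. Nothing available bears on the cause of this step.

As far as these compounds go, it remains open whether the step belongs to the bromine, the sulfur or the ring. Analogues carrying chlorine instead of bromine, or an amine nitrogen instead of sulfur, would begin to separate these parts.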